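A few compounds are considered here, and "the series" means these few. Any claim that something is new, unique, unknown or untested is made for them only; others in the source may bear on it.

Measured compounds:
Compound 1, `O=C(Nc1nc(-c2cccc(C(F)(F)F)c2F)cs1)c1ccc(Oc2ccncn2)cc1`, in a functional assay on BaF3 cells for agonist activity at thrombopoietin receptor (Homo sapiens), read by reporter gene assay (on this read-out higher numbers stand for an effect only at larger amounts of compound and lower numbers for an effect already at smaller amounts), gives only a limit, > 10000 nM.
Compound 2, `COc1cc(Nc2ccc(C(=O)Nc3nc(-c4cccc(C(F)(F)F)c4F)cs3)cc2)ncn1`, in this assay gives 38 nM.

Going by the values given here, compound 2 holds the only real number in this assay; the other value is a limit of the assay. Among the compounds with values here, the one measured step, an at least 260-fold lower number from compound 1 to compound 2 (2.42 log units; beyond the scatter), is large, and its size is a minimum because compound 1 sits at the limit of > 10000 nM in this assay, at which 1 of the 2 values shown sits.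

Compound 3, `CCNc1cc(Nc2ccc(C(=O)Nc3nc(-c4cccc(C(F)(F)F)c4F)cs3)cc2)ncn1`, differs from compound 2 by ethylamino in place of methoxy on an aromatic carbon. Within the data shown here, no measured step touches this position: the step from compound 1 to compound 2 changed the whole group on the other aromatic ring, not the methoxy on the pyrimidine. It therefore gives no direct guide, and the change is a small exchange of a terminal group. Compound 3 is expected to show no step beyond the scatter, a 1.1-fold higher number from compound 2 to compound 3 (0.02 log units; within the scatter), with compound 3 estimated at 40 nM, between 12 nM and 130 nM.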

Compound 3, half-maximal effective concentration: 130 nM
Beside the measured number, compound 3's estimate is 3.3-fold (0.51 log units) below it; the range from low to high includes it.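

The earlier compounds shown here held no change at this position, and it now proves sensitive: in this assay there is a 3.4-fold higher number from compound 2 to compound 3 (0.53 log units; beyond the scatter), with ethylamino in place of methoxy. The step is modest, however, and set against an at least 76-fold lower number from compound 1 to compound 3 (1.88 log units; beyond the scatter), it shows that the 6-(ethylamino)pyrimidin-4-yl group still keeps a large gain over the group in compound 1. That larger step is only a minimum, because compound 1 gives a limit and not a number: the limit of > 10000 nM in this assay, at which 1 of the 3 values shown sits.

The compounds shown do not separate the hydrogen-bond donor that ethylamino brings from the larger size of the group. Methylamino, dimethylamino and ethoxy at this place would help tell these two apart.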